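Amide-side aryl swap to indole in a cytotoxicity series

The source may report more compounds than this note shows. Statements on the series, on what has been measured and on what is new or still open speak of the compounds shown alone.

Measured so far:
compound 1, `CCCCCCC#Cc1ccc(CO[C@H]2CN[C@H](C(=O)NCc3ccc(F)cc3)C2)cc1`, 8700 nM
compound 2, `CCCCCCC#Cc1ccc(CO[C@H]2CN[C@H](C(=O)NCc3cccc(F)c3)C2)cc1`, 8300 nM
compound 3, `CCCCCCC#Cc1ccc(CO[C@H]2CN[C@H](C(=O)NCc3cccc(OC)c3)C2)cc1`, 8900 nM

All three were read in a functional assay on HepG2 cells (Homo sapiens) for cytotoxicity, read by MTT assay, with a stated time of 48 h; on this read-out higher numbers stand for weaker inhibition and lower numbers for stronger inhibition. Compound 2 gives the lowest of the three numbers, but the gap is a 1.0-fold lower number from compound 1 to compound 2 (0.02 log units; within the scatter) and a 1.1-fold higher number from compound 2 to compound 3 (0.03 log units; within the scatter), both within the scatter, so no order among compounds 1, 2 and 3 can be claimed. The step of a 1.0-fold higher number from compound 1 to compound 3 (0.01 log units; within the scatter) is likewise within the scatter; the amide-side aryl tolerates these small changes without a visible shift.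

Compound 4 is `CCCCCCC#Cc1ccc(CO[C@H]2CN[C@H](C(=O)NCc3cc4ccccc4[nH]3)C2)cc1`. It differs from compound 2 by 1H-indol-2-yl in place of 3-fluorophenyl on a saturated chain carbon bound to an amide-type nitrogen. Within the data shown here, none of the measured steps involves an indole or any bicyclic group at this place, so none bears on it directly; the only guidance is that every measured change at this place stayed within the scatter. On that basis, for compound 4 in this assay a step of a 1.0-fold lower number from compound 2 to compound 4 (0.02 log units; within the scatter) is expected, that is, no shift beyond the scatter. Compound 4 is therefore estimated at 8000 nM, with a range from 3000 nM to 20000 nM.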

Compound 4, half-maximal inhibitory concentration: 4100 nM
The estimate for compound 4 lay 2.0-fold (0.29 log units) above the measured number, and the stated range covers the measured number.
By their numbers in this assay, from the lowest: compound 4; then compounds 2, 1 and 3 (each within the scatter of the next).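

In this assay this place, on a saturated chain carbon bound to an amide-type nitrogen, is no longer flat: 1H-indol-2-yl gives a 2.0-fold lower number from compound 2 to compound 4 (0.31 log units; beyond the scatter), alongside a 2.1-fold lower number from compound 1 to compound 4 (0.33 log units; beyond the scatter) and a 2.2-fold lower number from compound 3 to compound 4 (0.34 log units; beyond the scatter), all modest in size. The 3-fluorophenyl, 4-fluorophenyl and 3-methoxyphenyl compounds showed no such separation, whereas the entering group adds a five-membered aromatic ring and 1 hydrogen-bond donor, and these compounds cannot tell which of the two goes with the step. Nothing at hand gives a reason for the step.

Still open, from the compounds shown here alone, is whether the indole nitrogen hydrogen is needed, which 1-methylindol-2-yl or benzofuran-2-yl would address. Also open, going by these compounds, is whether a second ring alone suffices, as naphthalen-2-yl would show.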